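The compounds below may be only part of what the source reports. "The series", "measured", "known", "first", "only" and "open" are said of these compounds alone.

Compound 1 `O=c1nc(-c2ccccc2)c2cc(-c3cccnc3)ccc2[nH]1`: > 50000 nM, a limit.
Compound 2 `Cc1ccccc1-c1nc(=O)[nH]c2ccc(-c3cc[nH]n3)cc12`: > 50000 nM, a limit.

In an ADME assay on L6 cells (Rattus norvegicus) for cytotoxicity, read by fluorescence and resazurin assay, with a stated time of 72 h (on this read-out lower numbers stand for an effect already at smaller amounts and higher numbers for an effect only at larger amounts of compound), compound 2 stands at a limit and has no exact number, and the same holds for compound 1. The evidence so far is the limit of > 50000 nM in this assay, at which 2 of the 2 values shown sit. Compound 3 `O=c1nc(C2CCC2)c2cc(-c3cc[nH]n3)ccc2[nH]1` has cyclobutyl in place of 2-methylphenyl on an aromatic carbon, next to the ring nitrogen (cyclobutyl in place of 2-methylphenyl on an aromatic carbon). For the measured compounds named here, no measured step is available as a guide. In this assay, the expected change an at least 1.1-fold lower number from compound 2 to compound 3 (0.04 log units; that floor lies within the scatter) is none beyond the scatter. For compound 3 the estimated value is 45000 nM, with an expected range from 15000 nM to 60000 nM.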

Compound 3, half-maximal effective concentration: > 50000 nM
Compound 3: only a limit was reported (the forecaster's own chance of this, stated with the estimate: 70%); middle value at least 1.1-fold (0.04 log units) from the limit.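

Compound 2 and compound 3 each give only a limit in this assay, so no step can be read between them. The compounds shown leave open whether cyclobutyl in place of 2-methylphenyl changes the read-out at all, as all three share one limit: the limit of > 50000 nM in this assay, at which 3 of the 3 values shown sit.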